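This account rests on a few compounds, and the source may have more. Where it says the series, first, only, none or still open, it means among the compounds named here.

Working notes on the series.

Compound 1 `NC(=O)c1ccccc1Cn1cc(-c2ccc3cn[nH]c3c2)ccc1=O` carries a carbamoyl on the six-membered aromatic ring of carbon only that hangs from the shared core. In an assay for inhibition of MAP kinase-interacting serine/threonine-protein kinase 2 (Homo sapiens), read by luminescence and ADP-Glo, with a stated time of 2 h (a lower number here means a stronger inhibitor, a higher number a weaker inhibitor), compound 1 gives 340 nM, the highest of the two numbers in hand. Compound 2 `O=c1ccc(-c2n[nH]c3ncc(Br)cc23)cn1Cc1ccccc1`, which has a different core and an unsubstituted ring on the same arm, gives 12 nM in this assay; the gap between the two values lies beyond the scatter, but the two compounds differ in more than one place, so nothing is drawn from that pair.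

Compound 3 `O=c1ccc(-c2ccc3cn[nH]c3c2)cn1Cc1ccccc1F` is the next entry. (fluoro in place of carbamoyl on an aromatic carbon). Among the compounds with values here, with no measured pair of this kind, the step is expected to be modest: a move to a lower number of about a 1.7-fold lower number from compound 1 to compound 3 (0.23 log units; within the scatter), close to the edge of the scatter. Compound 3 is therefore estimated at 200 nM in this assay, within 60 nM to 700 nM.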

Compound 3, half-maximal inhibitory concentration: 37 nM
Beside the measured number, compound 3's estimate is 5.4-fold (0.73 log units) above it, outside the stated range (below it).
By their numbers in this assay, from the lowest: compound 2; then compound 3; then compound 1.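

Within the data shown here, at the place on the six-membered aromatic ring of carbon only, ortho to a large group, the change from carbamoyl to fluoro gives in this assay the first single-place comparison: a 9.2-fold lower number from compound 1 to compound 3 (0.96 log units; beyond the scatter) with the core held constant. The carbamoyl is therefore not required at this place for inhibition in this series, as fluoro, with 0 hydrogen-bond donors and 0 hydrogen-bond acceptors, carries the lower number. No measurement in hand accounts for the size of this step.

Whether the lower number follows from the loss of carbamoyl or the arrival of fluoro stays open: the compounds shown include no core of compound 1 with an unsubstituted ring, or with chloro, methoxy or an amine at this place. Compound 2 cannot settle this, as it differs from compound 3 in more than one place.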